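Methoxy for ethylsulfanyl on the shared core

This account rests on a few compounds, and the source may have more. Where it says the series, first, only, none or still open, it means among the compounds named here.

Compound 1 `CCSc1nn2cc(-c3cc4ccccc4o3)nc2s1` carries an ethylsulfanyl group on the shared core; in a functional assay on HEK293 cells for antagonist activity at proteinase-activated receptor 4 (Homo sapiens), read by FLIPR and calcium flux, with a stated time of 30 min (on this read-out lower numbers stand for stronger inhibition and higher numbers for weaker inhibition), compound 1 gives 2900 nM. Compound 2 `COc1cc(OCc2ccccc2OCc2ccccc2)c2cc(-c3cn4nc(OC)sc4n3)oc2c1` gives 3.2 nM in this assay, so compound 1 holds the higher of the two numbers measured, the gap being beyond the scatter. Within the data shown here, compound 2 differs from compound 1 in more than one place, so the two values show only that the pair lies far apart, not which change carries the gap. On these data alone, compound 3 `COc1nn2cc(-c3cc4ccccc4o3)nc2s1` is untested; it differs from compound 1 by methoxy in place of ethylsulfanyl on an aromatic carbon. Among the measured compounds shown here, no single step of this kind has been measured, so the expectation rests on the two values alone. The expected step of a 2.9-fold lower number from compound 1 to compound 3 (0.46 log units; beyond the scatter) is a moderate fall, beyond the scatter. The estimate for compound 3 in this assay is 1000 nM, with a range from 200 nM to 5000 nM.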

Compound 3, half-maximal inhibitory concentration: 4 nM
Estimate against measurement, compound 3: 250-fold (2.40 log units) above; measured number below the stated range.
By their numbers in this assay, from the lowest: compounds 2 and 3 (each within the scatter of the next); then compound 1.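

In this assay, methoxy in place of ethylsulfanyl on an aromatic carbon next to the ring sulfur gives a 730-fold lower number from compound 1 to compound 3 (2.86 log units; beyond the scatter), the first one-place step read in the series, so this position on the shared core is highly sensitive to the group it carries. The step is large although the counts barely change: ethylsulfanyl has 3 heavy atoms and methoxy 2, and both have 1 hydrogen-bond acceptor, 0 hydrogen-bond donors and no net charge. No measurement on hand accounts for the size of the step.

The change swaps sulfur for oxygen and shortens the chain at once, so methylsulfanyl and ethoxy would be needed to tell these two apart. Also open, on these data alone, are how an amine at this position compares with methoxy, and whether ethylsulfanyl costs as much on the rest of compound 2.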